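The compounds below may be only part of what the source reports. "The series", "measured", "known", "first", "only" and "open" are said of these compounds alone.

In a functional assay on HL-60 cells (Homo sapiens) for cytotoxicity, read by luminescence and CellTiter-Glo, with a stated time of 3 days (on this read-out higher numbers stand for weaker inhibition and lower numbers for stronger inhibition), compound 1 (`O=C(Nc1cc(C(F)(F)F)cc(C(F)(F)F)c1)c1cc(F)ccc1O`) gives 320 nM and compound 2 (`O=C(Nc1cc(C(F)(F)F)cc(C(F)(F)F)c1)c1ccc(Cl)cc1O`) gives 200 nM on a shared core. Among the compounds with values here, these are the only two numbers so far, and the single step between them (a 1.6-fold lower number from compound 1 to compound 2 (0.20 log units; within the scatter)) does not set compound 2 apart from compound 1. Compound 3 (`O=C(Nc1cc(C(F)(F)F)cc(C(F)(F)F)c1)c1cc(Br)ccc1O`) has 5-bromo-2-hydroxyphenyl in place of the 4-chloro-2-hydroxyphenyl of compound 2, on a carbonyl carbon whose other neighbour is an amide-type nitrogen (5-bromo-2-hydroxyphenyl in place of 4-chloro-2-hydroxyphenyl on a carbonyl carbon). Within the data shown here, only the step from compound 1 to compound 2 bears on this, as it too exchanges one halogen-bearing hydroxyphenyl group for another. Since that exchange stayed small (a 1.6-fold lower number from compound 1 to compound 2 (0.20 log units; within the scatter)) no shift beyond the scatter is expected in this assay here, and the estimated move (a 1.2-fold higher number from compound 2 to compound 3 (0.06 log units; within the scatter)) has no meaningful direction. For compound 3 the estimated value is 230 nM with an expected range from 90 nM to 600 nM around it.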

Compound 3, half-maximal inhibitory concentration: 290 nM
Estimate against measurement, compound 3: 1.3-fold (0.10 log units) below; low and high end bracket the measured number.
By their numbers in this assay, from the lowest: compounds 2, 3 and 1 (each within the scatter of the next).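

In this assay, changing both the halogen and its place on the hydroxyphenyl group gives no readable difference on this carbonyl carbon (the step is a 1.5-fold higher number from compound 2 to compound 3 (0.16 log units; within the scatter)). Within the data shown here, the exchange of bromo for fluoro on an aromatic carbon is the first comparison of these two halogens, and it also gives no readable difference (a 1.1-fold lower number from compound 1 to compound 3 (0.04 log units; within the scatter)). Nothing available explains why these halogen exchanges stay within the scatter.

On these data alone, all three compounds carry one halogen on the hydroxyphenyl group, so it remains open how an amine, a nitrile or a methoxy group would read in place of that halogen. As far as these compounds go, it is equally open whether the hydroxyl of that group can give way to a methoxy group, or either trifluoromethyl group to a nitrile.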